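A few compounds are considered here, and "the series" means these few. Any claim that something is new, unique, unknown or untested is made for them only; others in the source may bear on it.

Measured compounds in a functional assay on HEK293 cells for agonist activity at Free fatty acid receptor 1 (Homo sapiens), read by fluorescence and calcium flux, with a stated time of 10 min; on this read-out higher numbers stand for larger maximal responses and lower numbers for smaller maximal responses:
compound 1 `CC#C[C@@H](CC(=O)O)c1ccc(OC[C@H]2COc3ccc(Cl)cc3O2)cc1`, 86%
compound 2 `CC#C[C@@H](CC(=O)O)c1ccc(OC[C@H]2COc3ccccc3O2)cc1`, 70%
compound 3 `CC#C[C@@H](CC(=O)O)c1ccc(OC[C@H]2COc3ccc(S(C)(=O)=O)cc3O2)cc1`, 55%

Compound 3 stands lowest of the three: the steps of a number 31 percentage points lower from compound 1 to compound 3 (beyond the scatter) and a number 15 percentage points lower from compound 2 to compound 3 (beyond the scatter) both lie beyond the scatter, so compound 3 is the weakest on maximal response in this assay. Compound 4 `CC#C[C@@H](CC(=O)O)c1ccc(OC[C@H]2COc3ccc(C(=O)N4CCOCC4)cc3O2)cc1` differs from compound 3 by (morpholin-4-yl)carbonyl in place of methylsulfonyl on an aromatic carbon. Going by the values given here, no measured step involves a (morpholin-4-yl)carbonyl at this carbon; the steps of a number 16 percentage points lower from compound 1 to compound 2 (beyond the scatter), a number 31 percentage points lower from compound 1 to compound 3 (beyond the scatter) and a number 15 percentage points lower from compound 2 to compound 3 (beyond the scatter) show only that the group at this position shifts the maximal response by modest to large amounts. With compound 3 as nearest reference, the step to compound 4 is expected to stay within the scatter, a number 3 percentage points higher from compound 3 to compound 4 (within the scatter). Compound 4 is estimated at 58% in this assay, range 42% to 76%.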

Compound 4, largest response reached (Emax), in percent of the reference or control that the assay uses: 33%
Compound 4: middle estimate off by 25 percentage points, on the high side; the whole stated range lies above it.
By their numbers in this assay, from the lowest: compound 4; then compound 3; then compound 2; then compound 1.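

In this assay the change from methylsulfonyl to (morpholin-4-yl)carbonyl, with equal donor and acceptor counts and no net charge on either group, gives a number 22 percentage points lower from compound 3 to compound 4 (beyond the scatter) so these counts alone do not set the maximal response at this carbon. Against hydrogen and chloro the new group gives a number 37 percentage points lower from compound 2 to compound 4 (beyond the scatter) and a number 53 percentage points lower from compound 1 to compound 4 (beyond the scatter) and leaves compound 4 the weakest of the four. No evidence on the origin of this drop is available. Open, on these data alone, is whether the loss follows the morpholine ring or the carbonyl link; an open-chain dimethylaminocarbonyl or a carboxylic acid at this carbon would test this.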